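A Methoxy-to-Methylsulfonyl Swap on a Pyridine Analogue

The compounds below may be only part of what the source reports. "The series", "measured", "known", "first", "only" and "open" are said of these compounds alone.

Three compounds have been measured in an assay on HT-29 cells for inhibition of Serine-protein kinase ATM (Homo sapiens), read by fluorescence, with a stated time of 1 h; on this read-out higher numbers stand for weaker inhibition and lower numbers for stronger inhibition:

Compound 1, `CCC(CC)CNc1c(C(N)=O)cnc2ccc(-c3ccc(COC)cc3)cc12`, gives 373 nM.
Compound 2, `CCC(CC)CNc1c(C(N)=O)cnc2ccc(-c3ccc(CS(C)(=O)=O)cc3)cc12`, gives 70 nM.
Compound 3, `CCC(CC)CNc1c(C(N)=O)cnc2ccc(-c3ccc(COC)nc3)cc12`, gives 45 nM.

Compound 2 differs from compound 1 by methylsulfonyl in place of methoxy on a saturated chain carbon bound to an aromatic carbon, and this change brings a 5.3-fold lower number from compound 1 to compound 2 (0.73 log units; beyond the scatter). Compound 3 differs from compound 1 in the ring that carries the side group, namely (6-(methoxymethyl)pyridin-3-yl in place of 4-(methoxymethyl)phenyl on an aromatic carbon), which brings an 8.3-fold lower number from compound 1 to compound 3 (0.92 log units; beyond the scatter). Compound 3 has the lowest number of the three, though its value and that of compound 2 lie within the usual scatter of each other, so no order between those two is claimed.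

Compound 4, `CCC(CC)CNc1c(C(N)=O)cnc2ccc(-c3ccc(CS(C)(=O)=O)nc3)cc12`, has not been measured. It differs from compound 3 by methylsulfonyl in place of methoxy on a saturated chain carbon bound to an aromatic carbon, the same change, at the same place, that separates compound 1 and compound 2. The step from compound 3 to compound 4 in this assay is expected to be a 4.1-fold lower number from compound 3 to compound 4 (0.61 log units; beyond the scatter), a little smaller than the earlier one, because compound 1 to compound 2 gave a 5.3-fold lower number from compound 1 to compound 2 (0.73 log units; beyond the scatter) and two such gains need not add up in full. The estimate for compound 4 in this assay is 11 nM, expected to fall between 4 nM and 30 nM.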

Compound 4, half-maximal inhibitory concentration in the Serine-protein kinase ATM assay: 39 nM
The estimate for compound 4 lay 3.5-fold (0.55 log units) below the measured number; the whole stated range lies below it.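

In the Serine-protein kinase ATM assay, on the core of compound 3, the swap gives a 1.2-fold lower number from compound 3 to compound 4 (0.06 log units; within the scatter), so the step seen on the core of compound 1 does not carry over at its earlier size: the same change on two cores in the Serine-protein kinase ATM assay, a 5.3-fold lower number (0.73 log units; beyond the scatter) from compound 1 to compound 2 and a 1.2-fold lower number (0.06 log units; within the scatter) from compound 3 to compound 4, 4.6-fold (0.66 log units) apart, beyond the scatter of two such steps. In a physicochemical assay for lipophilicity, using the shake flask method, measured as octanol-water partition, at pH 7.4 (on this read-out lower numbers stand for lower lipophilicity and higher numbers for higher lipophilicity), compound 3 gives > 4.3, which is a limit of the assay and not a number. In the physicochemical assay compound 4 gives 3.1. In the physicochemical assay the same swap gives a number at least 1.20 log units lower from compound 3 to compound 4 (beyond the scatter), but this does not explain why the two steps in the Serine-protein kinase ATM assay differ, and two cores are too few to set a rule for the series.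

It remains open how large the step in the Serine-protein kinase ATM assay would be on a third core, and so whether either of the two steps shown is the more typical one. Going by these compounds, it is also open how an amine or a carboxylic acid in place of methylsulfonyl, at the same place on a saturated chain carbon bound to an aromatic carbon, would read in either assay.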